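The source may hold more compounds than are shown below. What is called first, only, known or untested is meant among the compounds shown, and "the series" means these compounds.

Measured so far in an assay for inhibition of Fatty-acid amide hydrolase 1 (Rattus norvegicus); a higher number here means a weaker inhibitor, a lower number a stronger inhibitor:
compound 1 `N#Cc1cccc(-c2cnc(C(=O)CCc3ccc(COc4ccccc4)cc3)o2)n1` — compound 1 gives 0.56 nM
compound 2 `O=C(CCc1ccc(COc2ccccc2)cc1)c1ncc(I)o1` — compound 2 gives 4 nM

Going by the values given here, compound 2 holds the higher of the two numbers in this assay; the only other compound is compound 1, and the step of a 7.1-fold higher number from compound 1 to compound 2 (0.85 log units; beyond the scatter) separates them.

Compound 3 `CNC(=O)c1cnc(C(=O)CCc2ccc(COc3ccccc3)cc2)o1` differs from compound 2 by methylcarbamoyl in place of iodo on an aromatic carbon. Among the compounds with values here, no measured pair tests this exact exchange. Within the data shown here, the one step that bears on it, a 7.1-fold higher number from compound 1 to compound 2 (0.85 log units; beyond the scatter), shows that a larger group at this carbon went with a lower number than iodo; methylcarbamoyl is a smaller entering group than the 6-cyanopyridin-2-yl it replaces there, so part of that gain is expected to return. The step expected is a 2.7-fold lower number from compound 2 to compound 3 (0.43 log units; beyond the scatter), and compound 3 is estimated at 1.5 nM, within 0.4 nM to 6 nM.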

Compound 3, inhibition constant: 3.6 nM
Estimate against measurement, compound 3: 2.4-fold (0.38 log units) below; the measured number falls inside the stated range.
By their numbers in this assay, from the lowest: compound 1; then compounds 3 and 2 (each within the scatter of the next).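

In this assay the exchange of iodo for methylcarbamoyl on the aromatic carbon next to the ring oxygen gives a 1.1-fold lower number from compound 2 to compound 3 (0.05 log units; within the scatter) and so shows no readable difference, despite the added heavy atoms, hydrogen-bond donor and hydrogen-bond acceptor. Against 6-cyanopyridin-2-yl, methylcarbamoyl gives a 6.4-fold higher number from compound 1 to compound 3 (0.81 log units; beyond the scatter) and stands with iodo, so at this carbon the lower number of compound 1 belongs to 6-cyanopyridin-2-yl alone among these groups. Nothing measured here accounts for this. As far as these compounds go, what stays open is whether the nitrile or the pyridine ring of 6-cyanopyridin-2-yl carries that gap. An unsubstituted pyridin-2-yl or a carboxylic acid at this carbon would extend the comparison.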